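From 4-methylpiperazin-1-yl to dimethylamino at the assay limit

A few compounds are considered here, and "the series" means these few. Any claim that something is new, unique, unknown or untested is made for them only; others in the source may bear on it.

Compound 1 `c1ccc(Nc2cc(CNCCN3CCCCC3)cc(CNCCN3CCCCC3)c2)c(CN2CCCCC2)c1`: > 100000 nM, a limit
Compound 2 `CN1CCN(Cc2ccccc2Nc2cc(CNCCN3CCCCC3)cc(CNCCN3CCCCC3)c2)CC1`: > 100000 nM, a limit

Both results come from an ADME assay on SH-SY5Y cells (Homo sapiens) for cytotoxicity, read by MTT assay, with a stated time of 72 h; on this read-out lower numbers stand for higher toxicity in this test and higher numbers for lower toxicity in this test. Compound 2 stands at the limit of > 100000 nM in this assay, at which 2 of the 2 values shown sit, so it offers a limit and no number. Compound 3 `CN(C)Cc1ccccc1Nc1cc(CNCCN2CCCCC2)cc(CNCCN2CCCCC2)c1` carries dimethylamino in place of 4-methylpiperazin-1-yl on a saturated chain carbon bound to an aromatic carbon. Within the data shown here, the one measured step at this place, a step that the two limits leave unreadable from compound 1 to compound 2, gives no size to carry over, so no step beyond the usual scatter is expected for compound 3, and no direction can be read. The expected outcome is a number no higher from compound 2 to compound 3 (the limit leaves the size open). Compound 3 is estimated at 100000 nM, with an expected range from 30000 nM to 100000 nM.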

Compound 3, half-maximal cytotoxic concentration: > 100000 nM
Compound 3 ended at the assay's limit (the forecaster's own chance of this, stated with the estimate: 75%); the middle value sits exactly at the limit.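

Compound 1, compound 2 and compound 3 all stand at a limit and not at a number, so no step among them can be read: the limit of > 100000 nM in this assay, at which 3 of the 3 values shown sit.

The compounds shown leave open how far each lies from that limit, and whether swapping these groups changes toxicity in this test at all.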